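The source may report more compounds than this note shows. Statements on the series, on what has been measured and on what is new or still open speak of the compounds shown alone.

Measured so far in a functional assay (trachea) with Cavia porcellus as the target; on this read-out higher numbers stand for weaker inhibition and lower numbers for stronger inhibition:
compound 1, `CCn1nc(-c2cccnc2)c2ccccc2c1=O`, gives 1320 nM;
compound 2, `CC(=O)OCCn1nc(-c2cccnc2)c2ccccc2c1=O`, gives 9770 nM.

Within the data shown here, of these two numbers compound 2 holds the higher one, and its only neighbour is compound 1. The step between them, a 7.4-fold higher number from compound 1 to compound 2 (0.87 log units; beyond the scatter), shows that a group put on this chain carbon can raise the number, that is, give weaker inhibition. Compound 3, `O=c1c2ccccc2c(-c2cccnc2)nn1CCCCSc1ncccn1`, has not yet been tested in this assay. It differs from compound 2 in a single place: 2-((pyrimidin-2-yl)sulfanyl)ethyl in place of acetoxy on a saturated chain carbon, two bonds along the chain from an aromatic nitrogen. Among the measured compounds shown here, only one measured step bears on this change, a 7.4-fold higher number from compound 1 to compound 2 (0.87 log units; beyond the scatter), and it concerns the same place on the chain but a different group going in. It says that filling this place raised the number once; it says nothing about how a larger group carrying a ring will behave. The direction is therefore uncertain: a number close to compound 2 seems most likely, while a return toward compound 1 cannot be ruled out. Compound 3 is expected to give about 5000 nM in this assay, within 1500 nM to 20000 nM. This corresponds to an expected step of a 2.0-fold lower number from compound 2 to compound 3 (0.29 log units; within the scatter).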

Compound 3, half-maximal inhibitory concentration: 6170 nM
Compound 3: the middle estimate sits 1.2-fold (0.09 log units) below what was measured; measured number inside the range.
By their numbers in this assay, from the lowest: compound 1; then compounds 3 and 2 (each within the scatter of the next).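

In this assay, putting 2-((pyrimidin-2-yl)sulfanyl)ethyl in place of acetoxy gives a 1.6-fold lower number from compound 2 to compound 3 (0.20 log units; within the scatter) and so does not separate the two compounds, even though the entering group has more heavy atoms, a sulfur and a six-membered aromatic ring. Compared with hydrogen at the same place, the new group gives a 4.7-fold higher number from compound 1 to compound 3 (0.67 log units; beyond the scatter) and so, like acetoxy, leaves inhibition weaker than in compound 1, which means that two quite different groups on this saturated chain carbon now point the same way. Nothing available here explains why these two groups end up within the scatter of each other.

As far as these compounds go, whether any group at this place can give a lower number than compound 1 stays open, and an amine or a carboxylic acid on the chain would test this with groups of a different kind from the two seen so far. It also remains unclear how much of the step to compound 3 belongs to the chain and how much to the sulfur and the ring, a question that a plain longer chain ending in neither could help to answer.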